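A few compounds are considered here, and "the series" means these few. Any claim that something is new, unique, unknown or untested is made for them only; others in the source may bear on it.

In a functional assay on A549 cells (Homo sapiens) for inhibition, read by sulforhodamine B assay (on this read-out higher numbers stand for weaker inhibition of growth and lower numbers for stronger inhibition of growth), compound 1 `Cc1ccc2[nH]c(-c3ccc(-c4ccc(-c5cccc(Cl)c5)cc4)cc3)nc2c1` gives 2800 nM, within the scatter of compound 3 `Oc1cccc2[nH]c(-c3ccc(-c4ccc(-c5cccc(Cl)c5)cc4)cc3)nc12` at 2400 nM, while compound 2 `Clc1cccc(-c2ccc(-c3ccc(-c4nc5ccccc5[nH]4)cc3)cc2)c1` stands well apart at 31100 nM. Compound 4 `Cc1ccc2[nH]c(-c3ccc(-c4ccc(-c5ccc(OC(F)(F)F)cc5)cc4)cc3)nc2c1` keeps the methyl group of compound 1 but has 4-(trifluoromethoxy)phenyl in place of 3-chlorophenyl on an aromatic carbon. The two measured steps, an 11-fold higher number from compound 1 to compound 2 (1.05 log units; beyond the scatter) and a 13-fold lower number from compound 2 to compound 3 (1.11 log units; beyond the scatter), were both large, yet each changes only one substituent on the shared core. Among the compounds with values here, no measured pair varies the group exchanged here, so neither step gives a size or direction for this change. In this assay the estimated step is therefore a 1.1-fold higher number from compound 1 to compound 4 (0.03 log units; within the scatter), with nothing beyond the scatter expected. For compound 4 the estimate is 3000 nM, expected to fall between 1000 nM and 10000 nM.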

Compound 4, concentration for 50% growth inhibition: 3560 nM
Compound 4: middle estimate off by 1.2-fold (0.07 log units), on the low side; the range from low to high includes it.
By their numbers in this assay, from the lowest: compounds 3, 1 and 4 (each within the scatter of the next); then compound 2.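

On this aromatic carbon, 4-(trifluoromethoxy)phenyl in place of 3-chlorophenyl gives a 1.3-fold higher number from compound 1 to compound 4 (0.10 log units; within the scatter) in this assay, so this place accepts the exchange with no change beyond the scatter. That holds although the entering group has more heavy atoms and a hydrogen-bond acceptor that the leaving group lacks. Nothing measured here bears on why the exchange changes so little. From the compounds shown here alone, whether an amine or a carboxylic acid on this phenyl ring would give a similar number remains open, as does the effect of this exchange on compound 2, which lacks the methyl group.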